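A Ring Exchange on an Amide-Type Nitrogen

The source may report more compounds than this note shows. Statements on the series, on what has been measured and on what is new or still open speak of the compounds shown alone.

In an ADME assay on a cell-free system (plasma, Mus musculus) for metabolic stability, tested at 1 uM (a lower number here means that the compound disappears faster, a higher number that the compound lasts longer), compound 1 (`C=CC(=O)NC1CCN(S(=O)(=O)c2ccc(C(=O)NCCCc3ccccc3)cc2)CC1`) gives > 6 h as a limit of the assay and not a number. From the compounds shown here alone, compound 2 (`C=CC(=O)NC1CCN(S(=O)(=O)c2ccc(C(=O)NCc3cccc4ccccc34)cc2)CC1`) gives > 6 h as a limit too, so its exact standing is unknown. Going by the values given here, the one measured step (a step that the two limits leave unreadable from compound 1 to compound 2) has no readable size, and the evidence (the limit of > 6 h in this assay, at which 2 of the 2 values shown sit) offers no measured size to carry forward. Compound 3 (`C=CC(=O)NC1CCN(S(=O)(=O)c2ccc(C(=O)NC3CCCc4ccccc43)cc2)CC1`) carries 1,2,3,4-tetrahydronaphthalen-1-yl in place of (naphthalen-1-yl)methyl on an amide-type nitrogen. The expected step (a step that the limit leaves unreadable from compound 2 to compound 3) in this assay is none beyond the scatter, in neither direction. The estimate for compound 3 is 8 h (expected range 4 h to 16 h).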

Compound 3, half-life: > 6 h
Compound 3: no number, only a limit; the forecaster's own chance of this, stated with the estimate: 80%; the middle value lies beyond the limit too.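

Compound 3 gives a limit and not a number, so no new step can be read from compound 1 or compound 2 to compound 3: the limit of > 6 h in this assay, at which 3 of the 3 values shown sit.

The compounds shown leave open how long each actually lasts in this assay, and whether either exchange on the amide-type nitrogen alters that.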